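Chain extension on the compound 1 core: compound 4

The source may hold more compounds than are shown below. What is called first, only, known or untested is meant among the compounds shown, and "the series" means these compounds.

Measured so far:
compound 1, `CC(CC(=O)O)CC(=O)c1c(CCCc2ccccc2)n(C)c2ccc(Cl)cc12`, 223 nM
compound 2, `C[C@@H](CC(=O)O)CC(=O)c1c([C@H](O)CCCCCc2ccccc2)n(C)c2ccc(Cl)cc12`, 750 nM
compound 3, `CC(CC(=O)O)CC(=O)n1c(CCCCCc2ccccc2)cc2ccc(Cl)cc21`, 2.1 nM

In a functional assay for antagonist activity at Oxoeicosanoid receptor 1 (Homo sapiens), read by fluorescence and calcium flux, with stated times of 2 min and 1 min (a higher number here means a weaker inhibitor, a lower number a stronger inhibitor), compound 1 gives 223 nM, which places it second highest of the three numbers. The nearest value is that of compound 2, which in this assay gives 750 nM, a gap beyond the usual scatter. The furthest is compound 3, which in this assay gives 2.1 nM, far lower and also beyond the scatter; compound 3 differs from compound 1 in more than one place, so its value says nothing on its own about any single change.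

Compound 4, `CC(CC(=O)O)CC(=O)c1c(CCCCCc2ccccc2)n(C)c2ccc(Cl)cc12`, is the next compound to be measured in this assay. Against compound 1 the change is phenethyl in place of phenyl on a saturated chain carbon, three bonds along the chain from an aromatic carbon. Within the data shown here, no directly comparable pair among the measured compounds isolates this change. Compound 2 carries a longer chain along with other differences and sits higher than compound 1; compound 3 sits far lower. The expectation for the step of a 1.5-fold lower number from compound 1 to compound 4 (0.17 log units; within the scatter) is therefore modest, toward a lower number, possibly within the scatter. On that basis compound 4 is estimated at 150 nM, with a range from 40 nM to 600 nM.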

Compound 4, half-maximal inhibitory concentration: 11 nM
Estimate against measurement, compound 4: 14-fold (1.13 log units) above; measured number outside the range, below it.
By their numbers in this assay, from the lowest: compound 3; then compound 4; then compound 1; then compound 2.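

In this assay, among these compounds, phenethyl in place of phenyl on a saturated chain carbon, three bonds along the chain from an aromatic carbon, gives a 20-fold lower number from compound 1 to compound 4 (1.31 log units; beyond the scatter), and this is the first change that can be read in one place. The terminal aromatic ring stays the same type of ring and the counts of hydrogen-bond donors and acceptors do not change, so at this position a change in chain length alone is enough to shift the number well beyond the scatter. No measurement at hand accounts for the size of this step.

As far as these compounds go, two chain lengths on the core of compound 1 give a single step, not a trend, so it remains open whether a longer chain would lower the number further or reverse the gain. Also open, from the compounds shown here alone, is whether the chain tolerates an ether oxygen or an amine in place of one of its carbons, and compound 2 and compound 3 differ from compound 4 in more than one place, so neither settles these questions.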